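Replacing the thiazolyl hydrazone of compound 2

The compounds below may be only part of what the source reports. "The series", "measured", "known", "first", "only" and "open" are said of these compounds alone.

Measured compounds in an assay on CHO-K1 cells for displacement of a labelled ligand from adenosine receptor A1 (Homo sapiens), read by scintillation counting, with a stated time of 60 min; on this read-out higher numbers stand for weaker inhibition and lower numbers for stronger inhibition:
compound 1 `Nc1nc(N/N=C/c2ccc(OCc3ccc(F)cc3)cc2)nc2c1ncn2[C@@H]1O[C@H](CO)[C@@H](O)[C@H]1O` gives 70 nM;
compound 2 `Nc1nc(N/N=C/c2cncs2)nc2c1ncn2[C@@H]1O[C@H](CO)[C@@H](O)[C@H]1O` gives 22 nM;
compound 3 `Nc1nc(N/N=C/c2ccc(-c3ccc(Br)cc3)o2)nc2c1ncn2[C@@H]1O[C@H](CO)[C@@H](O)[C@H]1O` gives 4.5 nM.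

Compound 2 stands second highest of the three numbers in this assay: compound 1 shows a higher number, beyond the scatter, and compound 3 a lower one, also beyond the scatter. Compound 4 `Nc1nc(N/N=C/c2cccnc2Cl)nc2c1ncn2[C@@H]1O[C@H](CO)[C@@H](O)[C@H]1O` differs from compound 2 by 2-chloropyridin-3-yl in place of 1,3-thiazol-5-yl on a carbon with a double bond to nitrogen. Among the compounds with values here, no pair of measured compounds shows this change, so the step from compound 2 to compound 4 has no direct precedent; the three numbers show that different arms at this position move the value in both directions. Compound 4 is expected to land near compound 2, with no step beyond the scatter, estimated at 35 nM in a range from 8 nM to 150 nM, meaning an expected step of a 1.6-fold higher number from compound 2 to compound 4 (0.20 log units; within the scatter).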

Compound 4, inhibition constant: 4.6 nM
Estimate against measurement, compound 4: 7.6-fold (0.88 log units) above; the whole stated range lies above it.
By their numbers in this assay, from the lowest: compounds 3 and 4 (each within the scatter of the next); then compound 2; then compound 1.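

In this assay, within the data shown here, 2-chloropyridin-3-yl in place of 1,3-thiazol-5-yl on a carbon with a double bond to nitrogen gives a 4.8-fold lower number from compound 2 to compound 4 (0.68 log units; beyond the scatter), the first change at this position that can be read on its own. It shows that this position responds to the swap of one aromatic ring for another, with the number moving down rather than staying put. Nothing at hand accounts for the size of this step. From the compounds shown here alone, whether the step belongs to the chlorine or to the ring itself stays open, as does how a plain pyridin-3-yl or a 2-methoxypyridin-3-yl arm would read in this assay.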